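Cyclopropyl in Place of Ethyl: An Expected Small Step

A few compounds are considered here, and "the series" means these few. Any claim that something is new, unique, unknown or untested is made for them only; others in the source may bear on it.

Of the compounds shown here, three of one core have been tested in a functional assay on NCI-H226 cells (Homo sapiens) for inhibition, read by MTT assay, with a stated time of 72 h; on this read-out higher numbers stand for weaker inhibition of growth and lower numbers for stronger inhibition of growth. Compound 1 `COC(=O)c1nc(C)n(-c2ccccc2C(F)(F)F)n1` gives 6130 nM. Compound 2 `COC(=O)c1nc(C)n(-c2ccc(OC)cc2)n1` is reported only as a limit of the assay, > 100000 nM, which is the limit of > 100000 nM in this assay, at which 1 of the 3 values shown sits. Compound 3 `CCc1nc(C(=O)OC)nn1-c1ccc(F)cc1` gives 71300 nM in this assay, the highest of the two numbers, with compound 1 a clear distance below it.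

Compound 4 `COC(=O)c1nc(C2CC2)n(-c2ccc(F)cc2)n1` has not yet been measured. It differs from compound 3 by cyclopropyl in place of ethyl on an aromatic carbon. For the measured compounds named here, no measured pair shows this change, so the expectation rests on the change itself, and a step of small size, likely within the scatter, is expected in this assay, with a slight lean toward stronger inhibition. Compound 4 is therefore estimated at 50000 nM, with a range from 15000 nM to 150000 nM, an expected step of a 1.4-fold lower number from compound 3 to compound 4 (0.15 log units; within the scatter).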

Compound 4, concentration for 50% growth inhibition: 16300 nM
For compound 4 the middle estimate is 3.1-fold (0.49 log units) above the measured one; measured number inside the range.
By their numbers in this assay, from the lowest: compound 1; then compound 4; then compound 3. At a limit, above all of these: compound 2.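

In this assay, cyclopropyl in place of ethyl on this aromatic carbon gives a 4.4-fold lower number from compound 3 to compound 4 (0.64 log units; beyond the scatter), so the group at this position, two ring bonds from the ring atom that bears the methoxycarbonyl group, changes the read-out. This is the only single-place step shown, as the earlier compounds offered no such pair. Nothing measured here accounts for the step.

The compounds shown leave open whether a longer chain such as propyl, or an amine, at this position would go further in the same direction. They also leave open whether the step would hold with a carboxylic acid in place of the methoxycarbonyl group.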